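Adding an amino group to compound 2

A few compounds are considered here, and "the series" means these few. Any claim that something is new, unique, unknown or untested is made for them only; others in the source may bear on it.

Compound 1 `CNc1ncnc2c1c(-c1ccco1)cn2[C@@H]1O[C@H](CO)[C@@H](O)[C@H]1O`: 850 nM
Compound 2 `O=c1[nH]cnc2c1c(-c1ccccc1)cn2[C@@H]1O[C@H](CO)[C@@H](O)[C@H]1O`: > 20000 nM (a limit)
Compound 3 `O=c1[nH]cnc2c1c(-c1cc3ccccc3o1)cn2[C@@H]1O[C@H](CO)[C@@H](O)[C@H]1O`: > 20000 nM (a limit)

All three results come from a functional assay on HepG2 cells (Homo sapiens) for antiproliferative activity, read by XTT assay, with a stated time of 72 h; a lower number here means a stronger inhibitor, a higher number a weaker inhibitor. Compound 2 stands at > 20000 nM, which is a limit and not a number. Its place in the series is the limit of > 20000 nM in this assay, at which 2 of the 3 values shown sit, so any step from it has only a limit as its starting point.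

Compound 4 `Nc1nc2c(c(-c3ccccc3)cn2[C@@H]2O[C@H](CO)[C@@H](O)[C@H]2O)c(=O)[nH]1` differs from compound 2 by one change: amino in place of hydrogen on an aromatic carbon. The new group sits between two ring nitrogen atoms of the six-membered aromatic ring.

For the measured compounds named here, the only measured step from compound 2 is a step that the two limits leave unreadable from compound 2 to compound 3. It concerns the phenyl group rather than the carbon changed here, and it gives no size to carry over. Going by the values given here, compound 1 gives a number, 850 nM, but it differs from compound 2 in more than one place, so it offers no measured step for this change.

Among the compounds with values here, with no readable step to support a shift in either direction, the expected outcome in this assay is a number no higher from compound 2 to compound 4 (the limit leaves the size open), with no step expected beyond the scatter. The estimate for compound 4 is 20000 nM, with an expected range from 6000 nM to 50000 nM.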

Compound 4, half-maximal inhibitory concentration: > 20000 nM
Compound 4 ended at the assay's limit; the forecaster's own chance of this, stated with the estimate: 80%; the middle value sits exactly at the limit.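

In this assay compound 4 gives > 20000 nM, a limit and not a number. Compound 2 also stands at a limit, and no step can be read between compound 2 and compound 4. The compounds shown leave open whether amino in place of hydrogen on an aromatic carbon shifts the activity of compound 2 at all.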